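Exchanging 1,3-thiazol-5-yl for 1,2,3-thiadiazol-4-yl

This account rests on a few compounds, and the source may have more. Where it says the series, first, only, none or still open, it means among the compounds named here.

Compound 1 `CC(C)CN1C(=O)c2ccccc2[C@H](C(=O)Nc2ccc(F)c(C#N)c2)[C@H]1c1ccsc1` gives < 1000 nM in a physicochemical assay for solubility, in phosphate buffer, with a stated time of 18 h, at pH 7 (a higher number here means a more soluble compound, a lower number a less soluble compound), and this is a limit of the assay, not a number. Compound 2 `CC(C)CN1C(=O)c2ccccc2[C@H](C(=O)Nc2ccc(F)c(C#N)c2)[C@H]1c1cncc(C#N)c1` gives 60000 nM in this assay. Compound 3 `CC(C)CN1C(=O)c2ccccc2[C@H](C(=O)Nc2ccc(F)c(C#N)c2)[C@H]1c1cncs1` gives 63000 nM. Within the data shown here, compound 3 therefore stands level with the only other true number, as the comparison shows: a 1.1-fold higher number from compound 2 to compound 3 (0.02 log units; within the scatter).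

Compound 4 `CC(C)CN1C(=O)c2ccccc2[C@H](C(=O)Nc2ccc(F)c(C#N)c2)[C@H]1c1csnn1` differs at one place, on a saturated ring carbon, where 1,2,3-thiadiazol-4-yl stands in place of 1,3-thiazol-5-yl: 1,2,3-thiadiazol-4-yl in place of 1,3-thiazol-5-yl on a saturated ring carbon.

Three measured steps exchange the group at this same place. Two of them replace thiophen-3-yl and are large: an at least 60-fold higher number from compound 1 to compound 2 (1.77 log units; beyond the scatter) and an at least 63-fold higher number from compound 1 to compound 3 (1.79 log units; beyond the scatter). Both start from a limit: the limit of < 1000 nM in this assay, at which 1 of the 3 values shown sits. They show that a change at this place can move the read-out a long way. The third step is the closer guide, since it joins the two compounds with true numbers, and their different rings leave them level: a 1.1-fold higher number from compound 2 to compound 3 (0.02 log units; within the scatter). On that basis, no step beyond the scatter is expected here.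

The expected step is a 1.1-fold lower number from compound 3 to compound 4 (0.02 log units; within the scatter). For compound 4 the estimated value in this assay is 60000 nM, with an expected range from 20000 nM to 150000 nM.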

Compound 4, solubility: 5000 nM
Compound 4: middle estimate off by 12-fold (1.08 log units), on the high side; the whole stated range lies above it.
By their numbers in this assay, from the lowest: compound 4; then compounds 2 and 3 (each within the scatter of the next). At a limit, below all of these: compound 1.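

The exchange of 1,3-thiazol-5-yl for 1,2,3-thiadiazol-4-yl keeps a five-membered aromatic ring of the same heavy-atom count on the saturated ring carbon, yet it is not neutral in this assay and gives a 13-fold lower number from compound 3 to compound 4 (1.10 log units; beyond the scatter). Compound 2 and compound 3 had stood level despite their different rings, but that level does not hold for every aromatic ring at this place, as the same new ring also gives a 12-fold lower number from compound 2 to compound 4 (1.08 log units; beyond the scatter). The new ring still compares favourably with thiophen-3-yl, with an at least 5.0-fold higher number from compound 1 to compound 4 (0.69 log units; beyond the scatter), although this step rests on compound 1, whose value is a limit and not a number: the limit of < 1000 nM in this assay, at which 1 of the 4 values shown sits.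

The measurements shown offer no explanation for the drop at this place. They leave open how a ring carrying an amine or a carboxylic acid would read at this position, and whether the same drop between these two rings would persist if the isobutyl group gave way to a longer chain.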